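Aryl Variation on a Shared Core: Predicting Compound 4

The compounds below may be only part of what the source reports. "The series", "measured", "known", "first", "only" and "open" are said of these compounds alone.

Measured compounds, with their values in a functional assay on KBVIN cells (Homo sapiens) for antiproliferative activity, read by sulforhodamine B assay, with a stated time of 3 days; on this read-out lower numbers stand for an effect already at smaller amounts and higher numbers for an effect only at larger amounts of compound:
- compound 1, `CCCOc1ccc(-c2cc(=O)c3c(o2)C(CC)(CC)C(=O)C(CC)=C3O)cc1`: 29.2 uM
- compound 2, `CCC1=C(O)c2c(oc(-c3cccc(OC)c3)cc2=O)C(CC)(CC)C1=O`: 1.22 uM
- compound 3, `CCC1=C(O)c2c(oc(-c3ccc(OC)c(OC)c3)cc2=O)C(CC)(CC)C1=O`: 1 uM

Compound 2 stands second highest of the three numbers in this assay. Its nearest neighbour is compound 3, which differs only by a methoxy in place of hydrogen on an aromatic carbon; that step, a 1.2-fold lower number from compound 2 to compound 3 (0.09 log units; within the scatter), lies within the scatter. Compound 1 carries a different aryl group and gives a far higher number, so the aryl group on the shared core clearly matters.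

Compound 4, `CCC1=C(O)c2c(oc(-c3cc(C)c(O)c(C)c3)cc2=O)C(CC)(CC)C1=O`, has not been measured in this assay. Its difference from compound 2 is 4-hydroxy-3,5-dimethylphenyl in place of 3-methoxyphenyl on an aromatic carbon. Within the data shown here, no measured step covers this exact change; the only one-place step, from compound 2 to compound 3, shows that adding a small group on the aryl ring left the number essentially unchanged. Among the measured compounds shown here, the new group is larger and brings a hydrogen-bond donor, which no measured compound tests. For compound 4 a step of a 2.0-fold higher number from compound 2 to compound 4 (0.31 log units; beyond the scatter) is therefore expected, with wide uncertainty. Compound 4 is estimated at 2.5 uM, between 0.6 uM and 12 uM.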

Compound 4, concentration for half-maximal effect: 8.9 uM
Beside the measured number, compound 4's estimate is 3.6-fold (0.55 log units) below it; measured number inside the range.
By their numbers in this assay, from the lowest: compounds 3 and 2 (each within the scatter of the next); then compound 4; then compound 1.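

In this assay, replacing 3-methoxyphenyl with 4-hydroxy-3,5-dimethylphenyl on the shared core gives a 7.3-fold higher number from compound 2 to compound 4 (0.86 log units; beyond the scatter). Among these compounds, the only earlier step at this aryl group, a 1.2-fold lower number from compound 2 to compound 3 (0.09 log units; within the scatter), showed no change that could be told from scatter, so this is the first one-place step to show that the number can move when the aryl group changes while the rest of the molecule stays the same. The change replaces the whole aryl group, and no available evidence explains the shift or separates the part played by the hydroxy from that of the two methyl groups.

An aryl ring carrying the hydroxy without the two methyl groups, or the two methyl groups without the hydroxy, would be needed to separate these parts. Going by these compounds, how this position would respond to an amine or a carboxylic acid on the aryl ring also remains open.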